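This account rests on a few compounds, and the source may have more. Where it says the series, first, only, none or still open, it means among the compounds named here.

For the measured compounds named here, in a functional assay on MDA-MB-468 cells (Homo sapiens) for antiproliferative activity, read by sulforhodamine B assay, with a stated time of 72 h (a lower number here means a stronger inhibitor, a higher number a weaker inhibitor), compound 2 `COc1ccc2nc(Cl)c(/C=C\c3ccc(F)cc3)cc2c1` gives 15200 nM, the only actual number so far. Compound 1 `COc1ccc2nc(Cl)c(/C=C/c3ccc(C(F)(F)F)cc3)cc2c1`, drawn E, gives > 50000 nM, which is a limit of the assay and not a number. Compound 3 `COc1ccc2nc(Cl)c(/C=C/c3ccc(F)cc3)cc2c1` differs from compound 2 by the two compounds have the same atoms and bonds and differ only in configuration as drawn: 1 of 1 stereo elements differ; a double bond is drawn Z in compound 2 and E in compound 3: the same atoms and bonds, with a double bond drawn Z in compound 2 and E in compound 3. Going by the values given here, with that E-drawn limit as the only guide, a modest move toward weaker inhibition is expected, an estimated 1.8-fold higher number from compound 2 to compound 3 (0.27 log units; within the scatter). For compound 3 the expected value is 28000 nM, with an estimated range of 11000 nM to 50000 nM.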

Compound 3, half-maximal inhibitory concentration: 14800 nM
The estimate for compound 3 lay 1.9-fold (0.28 log units) above the measured number; the measured number falls inside the stated range.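

In this assay, turning the double bond from Z to E gives a 1.0-fold lower number from compound 2 to compound 3 (0.01 log units; within the scatter), so with fluoro on the aromatic carbon the drawn configuration shows no difference beyond the scatter. With the E double bond held fixed, fluoro in place of trifluoromethyl on an aromatic carbon gives an at least 3.3-fold lower number from compound 1 to compound 3 (0.52 log units; beyond the scatter). Compound 1 gives > 50000 nM, which is a limit of the assay and not a number.

From the compounds shown here alone, whether Z and E also match with trifluoromethyl on that carbon remains open. So does the effect of an amine or a carboxylic acid in place of fluoro there.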